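Cyclohexyl to 4-bromophenyl on the ether chain: cytotoxicity outlook

The source may hold more compounds than are shown below. What is called first, only, known or untested is meant among the compounds shown, and "the series" means these compounds.

The series shares one core, seen in compound 1 `CCC1(Cc2ccccc2)OS(=O)(=O)C=C1OCC#N`, where the chain on the oxygen carries a cyano group. Compound 2 `CCC1(Cc2ccccc2)OS(=O)(=O)C=C1OCCCc1ccccc1` carries phenethyl there, compound 3 `CCC1(Cc2ccccc2)OS(=O)(=O)C=C1OCC1CCCCC1` cyclohexyl. In an ADME assay on HEL cells (Homo sapiens) for cytotoxicity, with a stated time of 3 days (a higher number here means that more compound is tolerated, a lower number that less compound is tolerated), compound 1 gives only a limit, > 200000 nM. In this assay compound 2 gives 133000 nM. For compound 3 this assay again reports only a limit, > 200000 nM. The steps are therefore weakly readable: an at least 1.5-fold lower number from compound 1 to compound 2 (0.17 log units; that floor lies within the scatter); an at least 1.5-fold higher number from compound 2 to compound 3 (0.17 log units; that floor lies within the scatter); a step that the two limits leave unreadable from compound 1 to compound 3. Two of the three values sit at the same limit (the limit of > 200000 nM in this assay, at which 2 of the 3 values shown sit).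

Compound 4 `CCC1(Cc2ccccc2)OS(=O)(=O)C=C1OCc1ccc(Br)cc1` differs from compound 3 in one place: 4-bromophenyl in place of cyclohexyl on a saturated chain carbon bound to an oxygen on an unsaturated carbon. For the measured compounds named here, the only measured step that bears on it is the one from phenethyl to cyclohexyl, which does not reach beyond the scatter, so no step beyond the scatter is expected in this assay. The likeliest outcome is a return toward the region of compound 2, which gives 133000 nM. Compound 4 is therefore estimated at 150000 nM, between 60000 nM and 300000 nM. The expected step is an at least 1.3-fold lower number from compound 3 to compound 4 (0.12 log units; that floor lies within the scatter).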

Compound 4, half-maximal cytotoxic concentration: 171000 nM
The estimate for compound 4 lay 1.1-fold (0.06 log units) below the measured number, within the range that was stated.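

In this assay, the 4-bromophenyl group gives a readable number at this position, on a saturated chain carbon bound to an oxygen on an unsaturated carbon, and the comparison with the phenethyl chain is a full step: a 1.3-fold higher number from compound 2 to compound 4 (0.11 log units; within the scatter). The other two comparisons give only floors, an at least 1.1-fold lower number from compound 3 to compound 4 (0.06 log units; that floor lies within the scatter) and an at least 1.1-fold lower number from compound 1 to compound 4 (0.06 log units; that floor lies within the scatter), so no step at this position is yet shown beyond the scatter, across four quite different groups. These two steps remain floors because the numbers for compound 1 and compound 3 are limits: the limit of > 200000 nM in this assay, at which 2 of the 4 values shown sit.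

Going by these compounds, how far those two compounds truly lie from compound 4 stays open. Also open, on these data alone, are the share of the bromine, which an unsubstituted phenyl would test, and whether an amine or a carboxylic acid on this chain would move the number beyond the scatter.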